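Replacing the Benzyl Group of Compound 1

The source may hold more compounds than are shown below. What is called first, only, known or untested is meant among the compounds shown, and "the series" means these compounds.

In an ADME assay on cells (Peritoneal macrophage, Mus musculus, strain Balb/c) for cytotoxicity, read by resazurin assay, with a stated time of 72 h (a lower number here means that less compound is tolerated, a higher number that more compound is tolerated), compound 1 `CC1(Cc2cccc([N+](=O)[O-])c2)CC(S(=O)(=O)c2ccc(F)cc2)=C(c2ccc(/C(N)=N/O)cc2)O1` gives 86600 nM and compound 2 `COc1cc(CC2(C)CC(S(=O)(=O)c3ccc(F)cc3)=C(c3ccc(/C(N)=N/O)cc3)O2)cc(OC)c1OC` gives 92300 nM, a pair that lies within the usual scatter. Compound 3 `CC1(/C=C/c2ccc(C(F)(F)F)cc2)CC(S(=O)(=O)c2ccc(F)cc2)=C(c2ccc(/C(N)=N/O)cc2)O1` is still unmeasured: it carries 2-(4-(trifluoromethyl)phenyl)ethenyl in place of 3-nitrobenzyl on a saturated ring carbon. Going by the values given here, the only measured step, a 1.1-fold higher number from compound 1 to compound 2 (0.03 log units; within the scatter), put 3,4,5-trimethoxyphenyl in place of 3-nitrophenyl and stayed within the scatter, though it is a different change and only a loose guide. No step beyond the scatter is therefore expected in this assay, and the estimated step is a 1.2-fold lower number from compound 1 to compound 3 (0.06 log units; within the scatter). For compound 3 the expected value is 75000 nM, within an estimated range of 30000 nM to 190000 nM.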

Compound 3, half-maximal cytotoxic concentration: 43900 nM
Estimate against measurement, compound 3: 1.7-fold (0.23 log units) above, and the stated range covers the measured number.
By their numbers in this assay, from the lowest: compounds 3, 1 and 2 (each within the scatter of the next, the first and the last beyond it).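

In this assay, exchanging the whole group on this saturated ring carbon, not only its aromatic ring, gives a 2.0-fold lower number from compound 1 to compound 3 (0.30 log units; within the scatter). Even 2-(4-(trifluoromethyl)phenyl)ethenyl, which has 0 hydrogen-bond acceptors where 3-nitrobenzyl has 2, therefore gives no step beyond the scatter. Nothing measured here accounts for this result. Still open, from the compounds shown here alone, is whether a group ending in an amine or a carboxylic acid at this carbon would also stay within the scatter. Going by these compounds, a longer chain between this ring carbon and the aromatic ring is equally open.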